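The compounds below may be only part of what the source reports. "The series", "measured", "known", "first", "only" and "open" are said of these compounds alone.

Going by the values given here, in a functional assay on ECa-109 cells (Homo sapiens) for antiproliferative activity, read by MTT assay, with a stated time of 48 h (a higher number here means a weaker inhibitor, a lower number a stronger inhibitor), compound 1 `Cn1cc(C2=C(c3nn(CCCN4CCCCC4)c4ncccc34)C(=O)N(c3cccc4ccccc34)C2=O)c2ccccc21` gives 1830 nM, the only actual number so far. Compound 2 `Cn1cc(C2=C(c3nn(CCn4ccnc4)c4ncccc34)C(=O)NC2=O)c2ccccc21` is recorded only as a limit, > 100000 nM. Among the compounds with values here, no two measured compounds differ in just one place, so no single structural change has a measured size in this assay. Compound 3 `COc1ccc(N2C(=O)C(c3cn(C)c4ccccc34)=C(c3nn(CCCN4CCCCC4)c4ncccc34)C2=O)cc1` keeps the core of compound 1 and changes one group: 4-methoxyphenyl in place of naphthalen-1-yl on an amide-type nitrogen in a ring. The nitrogen still carries an aromatic ring, so the reading is anchored on compound 1 at 1830 nM, with only a modest loss of potency anticipated. The expected step of a 1.6-fold higher number from compound 1 to compound 3 (0.21 log units; within the scatter) is a small weakening, not far beyond the scatter. Compound 3 is expected at 3000 nM, within an estimated range from 1000 nM to 10000 nM.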

Compound 3, half-maximal inhibitory concentration: 3340 nM
The estimate for compound 3 lay 1.1-fold (0.05 log units) below the measured number; low and high end bracket the measured number.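

In this assay, placing 4-methoxyphenyl in place of naphthalen-1-yl on the amide-type nitrogen gives a 1.8-fold higher number from compound 1 to compound 3 (0.26 log units; within the scatter), the first step measured at this position. Compound 1 and compound 3 therefore cannot be told apart in this assay, although one six-membered aromatic ring of carbon only stands where there were two and a hydrogen-bond acceptor enters with the methoxy oxygen. At this position, then, the two aromatic groups read alike, and nothing shown gives a cause for that.

As far as these compounds go, it remains open whether the reading would hold with a group on this nitrogen that has no aromatic ring, such as methyl or a short alkyl chain. From the compounds shown here alone, it is equally open how a phenyl ring bearing a carboxylic acid or an amine would read there.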